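The source may hold more compounds than are shown below. What is called first, only, known or untested is meant among the compounds shown, and "the series" means these compounds.

Series notes. The parent here is compound 1 `c1cc(-c2ccn[nH]2)c2c(c1)C(c1ncc[nH]1)CC2`. Among the compounds with values here, in a functional assay on CHO cells for agonist activity at Alpha-1B adrenergic receptor (Homo sapiens), read by FLIPR and calcium flux (a higher number here means that more compound is needed for the effect, a lower number that less compound is needed), compound 1 gives 600 nM, the only numerical reading among the three compounds measured so far. Compound 2 `Cc1c(OCC2=NCCN2)ccc(Cl)c1NS(C)(=O)=O` reaches only a limit of the assay, > 10000 nM. Compound 3 `Clc1ccc2c(c1-c1ccn[nH]1)CCC2c1ncc[nH]1` likewise stops at a limit, > 10000 nM. Within the data shown here, the single one-point step measured, an at least 16-fold higher number from compound 1 to compound 3 (1.22 log units; beyond the scatter), is therefore large, and it rests on (the limit of > 10000 nM in this assay, at which 2 of the 3 values shown sit).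

Next in line is compound 4 `c1cc(-c2nccs2)c2c(c1)C(c1ncc[nH]1)CC2`. Relative to compound 1 the change is 1,3-thiazol-2-yl in place of 1H-pyrazol-5-yl on an aromatic carbon. Among the measured compounds shown here, no measured step bears directly on this exchange: the one step available concerns chloro in place of hydrogen on an aromatic carbon, not the five-membered ring. With a single numerical value in the set, any expectation is loosely founded. The exchange drops the one hydrogen-bond donor counted for compound 1 and adds an acceptor, so a move toward weaker activity of a 3.3-fold higher number from compound 1 to compound 4 (0.52 log units; beyond the scatter) is expected, and compound 4 is estimated at 2000 nM, within 400 nM to 10000 nM.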

Compound 4, half-maximal effective concentration: > 10000 nM
Compound 4 gave a limit, no number (the forecaster's own chance of this, stated with the estimate: 30%); middle value at least 5.0-fold (0.69 log units) away from the limit.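

This exchange shows that the aromatic carbon bearing the 1H-pyrazol-5-yl group of compound 1 does not tolerate every five-membered aromatic ring with 2 hetero atoms: the replacement keeps the same count of 5 heavy atoms, yet gives an at least 16-fold higher number from compound 1 to compound 4 (1.22 log units; beyond the scatter). Within the data shown here, the earlier step concerned only chloro in place of hydrogen on an aromatic carbon, so this is the first evidence on the ring itself. Compound 4 stops at a limit of the assay, and the true size of its step stays unknown, as does its order relative to the chloro step: the limit of > 10000 nM in this assay, at which 3 of the 4 values shown sit.

Whether the loss follows from the missing hydrogen-bond donor, the added sulfur or the altered nitrogen count remains unresolved. From the compounds shown here alone, how an amine or a carboxylic acid on the same aromatic carbon would read in this assay also remains open.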